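The source may report more compounds than this note shows. Statements on the series, on what has been measured and on what is new or still open speak of the compounds shown alone.

In a functional assay on PC-3 cells (Homo sapiens) for inhibition, read by MTT assay, with a stated time of 48 h (a higher number here means a weaker inhibitor, a lower number a stronger inhibitor), compound 3 `COc1cc(-c2nnc(SCc3ccc(C)cc3)n2-c2ccc(N(C)C)cc2)cc(OC)c1OC` gives 37300 nM. This lies within the scatter of compound 1 `COc1ccc(-n2c(SCc3ccc(C)cc3)nnc2-c2cc(OC)c(OC)c(OC)c2)cc1`, which gives 56500 nM. Both are weak results on this scale, and the two compounds differ by a 1.5-fold lower number from compound 1 to compound 3 (0.18 log units; within the scatter).

Compound 4 `COc1cc(-c2nnc(SCC(=O)C3CC3)n2-c2ccc(N(C)C)cc2)cc(OC)c1OC` keeps the dimethylamino group of compound 3 but has cyclopropylcarbonyl in place of 4-methylphenyl on a saturated chain carbon bound to a sulfur.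

The closest measured change also replaces 4-methylphenyl with a carbonyl-bearing group, and it leads to compound 2 `COc1ccc(-n2c(SCC(=O)c3ccc(OC)c(O)c3)nnc2-c2cc(OC)c(OC)c(OC)c2)cc1`. Compound 2 is reported only as a limit, > 60000 nM, not as a number. That change is an at least 1.0-fold higher number from compound 1 to compound 2 (0.02 log units; that floor lies within the scatter), so it shows no clear shift, although it does not show the true size of the step either. In this small set, (the limit of > 60000 nM in this assay, at which 1 of the 3 values shown sits).

With so little to go on, no step beyond the scatter is expected in this assay, though any shift would more likely be towards weaker inhibition. The estimated step is a 1.3-fold higher number from compound 3 to compound 4 (0.11 log units; within the scatter). For compound 4 the expected value is 48000 nM, with an estimated range from 22000 nM to 85000 nM.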

Compound 4, half-maximal inhibitory concentration: 45900 nM
The estimate for compound 4 lay 1.0-fold (0.02 log units) above the measured number, and the stated range covers the measured number.
By their numbers in this assay, from the lowest: compounds 3, 4 and 1 (each within the scatter of the next). At a limit, above all of these: compound 2.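

In this assay, the step for this change is a 1.2-fold higher number from compound 3 to compound 4 (0.09 log units; within the scatter), so a real number now shows the size of a swap to a carbonyl-bearing group at this place. On a saturated chain carbon bound to a sulfur, the six-membered aromatic ring of 4-methylphenyl can give way to the smaller three-membered ring and carbonyl of cyclopropylcarbonyl with no step beyond the scatter. The earlier carbonyl-bearing swap could not show this, as compound 2 is read only at a limit: the limit of > 60000 nM in this assay, at which 1 of the 4 values shown sits.

On these data alone, whether cyclopropylcarbonyl gives a similar number with methoxy in place of dimethylamino remains open. So does whether an amine or a carboxylic acid at this same place, or a longer chain, would move the number beyond the scatter.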